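This account rests on a few compounds, and the source may have more. Where it says the series, first, only, none or still open, it means among the compounds named here.

Series notes. Compound 3 `CN(CC(=O)N1CCN(c2ccccc2)CC1)C(=O)c1ccc(S(C)(=O)=O)c([N+](=O)[O-])c1` and compound 1 `CN(CC(=O)N1CCN(c2ccc(F)cc2)CC1)C(=O)c1ccc(S(C)(=O)=O)c([N+](=O)[O-])c1` share a core, as does compound 2 `CN(Cc1ccccc1)C(=O)CNC(=O)c1ccc(S(C)(=O)=O)c([N+](=O)[O-])c1`; how the core of compound 2 differs from that of compound 3 is not broken down here. In an assay on isolated protein for inhibition of thyroid hormone receptor alpha (Homo sapiens), read by fluorescence polarization (a higher number here means a weaker inhibitor, a lower number a stronger inhibitor), compound 3 gives only a limit, > 60000 nM. In this assay compound 1 likewise gives only a limit, > 60000 nM. Compound 2 gives only a limit as well, > 60000 nM. The change fluoro in place of hydrogen on an aromatic carbon thus yields a step that the two limits leave unreadable from compound 3 to compound 1, since every value sits at the limit of > 60000 nM in this assay, at which 3 of the 3 values shown sit. Compound 4 `CN(Cc1cccc(F)c1)C(=O)CNC(=O)c1ccc(S(C)(=O)=O)c([N+](=O)[O-])c1` is not yet measured; it differs from compound 2 by fluoro in place of hydrogen on an aromatic carbon, the same kind of change, but the place is meta to a large group, whereas in compound 1 it is para to a large group. With the parent already at the limit, the step is expected to be a step that the limit leaves unreadable from compound 2 to compound 4. Compound 4 is expected at 100000 nM, between 30000 nM and 300000 nM, most likely again only a limit.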

Compound 4, half-maximal inhibitory concentration: > 60000 nM
Compound 4 was reported as a limit (the forecaster's own chance of this, stated with the estimate: 90%); the middle value does not contradict the limit.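

No new step can be read between compound 2 and compound 4, as both give only a limit: the limit of > 60000 nM in this assay, at which 4 of the 4 values shown sit.

The compounds shown leave open what size the fluoro step has, and which changes to these cores would give a readable value.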